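The source may report more compounds than this note shows. Statements on the series, on what has been measured and on what is new or still open speak of the compounds shown alone.

Within the data shown here, compound 1 (`O=C(Nc1cc(C(F)(F)F)cc(C(F)(F)F)c1)c1cnc(Cl)nc1C(F)(F)C(F)(F)F`) is the only compound of this pair to give a number in an assay on Jurkat cells for activation of nuclear factor NF-kappa-B complex (Homo sapiens); on this read-out lower numbers stand for stronger inhibition and higher numbers for weaker inhibition: compound 1 gives 800 nM. Compound 2 (`Cc1cc(C(=O)Nc2cc(C(F)(F)F)cc(C(F)(F)F)c2)nc(Cl)n1`) is reported only as a limit of this assay; in this assay compound 2 gives > 10000 nM. Among the measured compounds shown here, the one further value beside compound 1 is therefore a limit and not a number, as the limit of > 10000 nM in this assay, at which 1 of the 2 values shown sits, states, so no measured step between two numbers is available here.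

Compound 3 (`CCCc1nc(Cl)ncc1C(=O)Nc1cc(C(F)(F)F)cc(C(F)(F)F)c1`) is not yet measured. It differs from compound 1 in one place: propyl in place of 1,1,2,2,2-pentafluoroethyl on an aromatic carbon. For the measured compounds named here, with no measured step of this kind to lean on, a moderate loss is expected, and the step from compound 1 to compound 3 is estimated to be a 3.1-fold higher number from compound 1 to compound 3 (0.49 log units; beyond the scatter). Compound 3 is thus expected to give about 2500 nM in this assay, within a range from 600 nM to 10000 nM.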

Compound 3, half-maximal inhibitory concentration: 500 nM
For compound 3 the middle estimate is 5.0-fold (0.70 log units) above the measured one, and the stated range ends above it.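

Among these compounds, the exchange of 1,1,2,2,2-pentafluoroethyl for propyl gives the first measured step at this position in this assay, and it reads as a 1.6-fold lower number from compound 1 to compound 3 (0.20 log units; within the scatter). The position next to the ring nitrogen therefore accepts a chain of carbon alone as well as the fluorinated chain, and the five fluorine atoms of the group that leaves are not needed to keep compound 3 level with compound 1 on this read-out. Nothing shown here gives a reason for this result.

The compounds shown leave open whether this tolerance extends to a longer chain such as butyl or hexyl, or to a cyclopropyl ring. They also leave open how a group carrying a heteroatom, such as an amine or a methoxy group, would fare at this position.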